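Adding a 4-chlorophenyl to a thiosemicarbazone nitrogen

A few compounds are considered here, and "the series" means these few. Any claim that something is new, unique, unknown or untested is made for them only; others in the source may bear on it.

Compound 1, `CCN(CC)CN1C(=O)/C(=N/NC(N)=S)c2cc(Cl)ccc21`: > 100000 nM
Compound 2, `CCN(CC)CN1C(=O)/C(=N/NC(=S)Nc2ccc(OC)cc2)c2ccccc21`: >= 4000 nM

Compound 1 was tested in an ADME assay on HeLa cells (Homo sapiens) for cytotoxicity; on this read-out higher numbers stand for lower toxicity in this test and lower numbers for higher toxicity in this test. In this assay compound 1 gives only a limit, > 100000 nM, not a number; it stands at the top of what is shown (the limit of > 100000 nM in this assay, at which 1 of the 2 values shown sits). Compound 2, which carries a 4-methoxyphenyl on the same nitrogen, also gives only a limit in this assay, >= 4000 nM, which is the other limit among the values shown (the limit of >= 4000 nM in this assay, at which 1 of the 2 values shown sits). Since both values are limits, no order between compound 1 and compound 2 can be read from them.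

Compound 3, `CCN(CC)CN1C(=O)/C(=N/NC(=S)Nc2ccc(Cl)cc2)c2cc(Cl)ccc21`, is not yet measured in this assay. It differs from compound 1 in one place: 4-chlorophenyl in place of hydrogen on an amide-type nitrogen. Among the compounds with values here, no measured step of this kind is available, so the direction is open; a move toward higher toxicity beyond the scatter is expected, though a result within the scatter cannot be excluded, and the expected step is an at least 5.0-fold lower number from compound 1 to compound 3 (0.69 log units; beyond the scatter). Compound 3 is expected to give about 20000 nM in this assay, within 4000 nM to 100000 nM.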

Compound 3, minimum cytotoxic concentration: 100000 nM
Beside the measured number, compound 3's estimate is 5.0-fold (0.70 log units) below it; low and high end bracket the measured number.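

Replacing hydrogen with 4-chlorophenyl on the amide-type nitrogen gives, in this assay, a number no higher from compound 1 to compound 3 (the limit leaves the size open). Within the data shown here, this is the first step readable at this position, and it shows that a substituent this large on the nitrogen is compatible with a value of compound 3 of 100000 nM, a number rather than a limit. Compound 1 gives only a limit, so the size of the change cannot be stated: the limit of > 100000 nM in this assay, at which 1 of the 3 values shown sits.

The compounds shown leave open whether any real shift lies behind this step, since only a number for compound 1 could settle that. They also leave open how a plain phenyl, a methyl or a longer alkyl chain on the same nitrogen would read in this assay.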